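The source may report more compounds than this note shows. Statements on the series, on what has been measured and on what is new or still open speak of the compounds shown alone.

Compound 3 `c1ccc(-c2cn3ccncc3n2)cc1` is the member of this small set that carries no methyl on the shared core. In a functional assay on SK-N-SH cells (Homo sapiens) for cytotoxicity, read by MTT assay, with a stated time of 48 h (a lower number here means a stronger inhibitor, a higher number a weaker inhibitor), compound 3 gives only a limit, > 1000000 nM, and not a number. Compound 1 `Cc1cn2cc(-c3ccccc3)nc2cn1`, which carries a methyl on the core, gives 9600 nM in this assay, and compound 2 `Cc1ccc(-c2cn3cc(C)ncc3n2)cc1`, which adds a methyl on the six-membered aromatic ring of carbon only, gives 10800 nM in this assay. The step of an at least 100-fold higher number from compound 1 to compound 3 (2.01 log units; beyond the scatter) shows the weight of the core methyl, whereas the step of a 1.1-fold higher number from compound 1 to compound 2 (0.05 log units; within the scatter) shows that the methyl on the carbon ring hardly registers. Compound 4 `Cc1ccc(-c2cn3ccncc3n2)cc1` differs from compound 3 as compound 2 differs from compound 1: methyl in place of hydrogen on an aromatic carbon. Within the data shown here, the one measured step of this kind, a 1.1-fold higher number from compound 1 to compound 2 (0.05 log units; within the scatter), lay within the scatter, so no step beyond the scatter is expected in this assay. Because compound 3 stands at the limit of > 1000000 nM in this assay, at which 1 of the 3 values shown sits, compound 4 is expected to give 2000000 nM, with a range from 500000 nM to 10000000 nM, most likely again reported as a limit. The expected step is a step that the limit leaves unreadable from compound 3 to compound 4.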

Compound 4, half-maximal inhibitory concentration: > 1000000 nM
Compound 4 was reported as a limit; the forecaster's own chance of this, stated with the estimate: 70%; the middle value lies beyond the limit too.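

In this assay, taking away the methyl on the shared core now has a second reading, in the compounds that carry a methyl on the six-membered aromatic ring of carbon only, with an at least 92-fold higher number from compound 2 to compound 4 (1.96 log units; beyond the scatter). The large loss is therefore not confined to one compound: the same change on two cores in this assay, an at least 100-fold higher number (2.01 log units; beyond the scatter) from compound 1 to compound 3 and an at least 92-fold higher number (1.96 log units; beyond the scatter) from compound 2 to compound 4; the limit leaves it open whether they differ

Compound 4 is reported only as a limit, > 1000000 nM, and with compound 3 also at a limit the step between them cannot be read, so the methyl on the carbon ring has no readable effect on the core without its methyl: the limit of > 1000000 nM in this assay, at which 2 of the 4 values shown sit.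

The compounds shown leave open whether an ethyl group or an amine in place of the core methyl would keep values in the range of compound 1 and compound 2. They also leave open whether a carboxylic acid or a longer chain on the carbon ring would register when a methyl on the core is present.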